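Removing a Ring Methyl and Liver Microsome Clearance

This account rests on a few compounds, and the source may have more. Where it says the series, first, only, none or still open, it means among the compounds named here.

Compound 1 `C[C@]1(O)C[C@](c2ccnc(C(F)(F)F)c2)([C@H](O)c2ccccn2)C1` was tested in an ADME assay on liver for metabolic stability, with Liver microsome (Homo sapiens) as the target, read by LC-MS, using microsomes, with a stated time of 5 h (a higher number here means faster removal of the compound, a lower number slower removal), and gives 66.7 mL/min/kg. Compound 2 `O[C@H](c1ccccn1)[C@]1(c2ccnc(C(F)(F)F)c2)C[C@H](O)C1` differs from compound 1 by hydrogen in place of methyl on a saturated ring carbon; in this assay compound 2 gives 33.3 mL/min/kg, so that a 2.0-fold lower number from compound 1 to compound 2 (0.30 log units; within the scatter). Compound 3 `C[C@]1(O)C[C@@](c2cc(C(F)(F)F)ccn2)([C@H](O)c2ccccn2)C1` has the same atoms as compound 1 joined differently; the difference between the two cores is not broken down here. In this assay compound 3 gives 33.3 mL/min/kg, level with compound 2 at the digits reported. Compound 4 `O[C@H](c1ccccn1)[C@]1(c2cc(C(F)(F)F)ccn2)C[C@@H](O)C1` has not yet been measured and differs from compound 3 by hydrogen in place of methyl on a saturated ring carbon, the same change at the same place as before. Because compound 3 gives 33.3 mL/min/kg, compound 4 is expected to give 20 mL/min/kg, between 10 mL/min/kg and 45 mL/min/kg. That expectation means a 1.7-fold lower number from compound 3 to compound 4 (0.22 log units; within the scatter), resting on the earlier 2.0-fold lower number from compound 1 to compound 2 (0.30 log units; within the scatter).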

Compound 4, clearance: 33.3 mL/min/kg
Estimate against measurement, compound 4: 1.7-fold (0.22 log units) below; low and high end bracket the measured number.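

In this assay, hydrogen in place of methyl on the saturated ring carbon gives no change at the digits printed from compound 3 to compound 4 (within the scatter) on this second core. Set beside the earlier step, the two results cannot be told apart: the same change on two cores in this assay, a 2.0-fold lower number (0.30 log units; within the scatter) from compound 1 to compound 2 and no change at the digits printed (within the scatter) from compound 3 to compound 4, 2.0-fold (0.30 log units) apart, within the scatter of two such steps. So the change carries from one core to the other only in the sense that neither step lies beyond the scatter; these two pairs show neither a real effect of the methyl on clearance in either core nor a real difference between the cores.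

The compounds shown leave open what an amine or a longer chain in place of that methyl would do. They also leave open whether the same holds when a nitrile replaces the trifluoromethyl group.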